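This account rests on a few compounds, and the source may have more. Where it says the series, first, only, none or still open, it means among the compounds named here.

Working notes on the series. Compound 1 `CCCCc1cc2cn(COCCO)c(=O)nc2o1`, compound 3 `CCCCCCCc1cc2cn(COCCO)c(=O)nc2o1` and compound 2 `CCCCCCCCCCCc1cc2cn(COCCO)c(O)nc-2n1` have been run in a functional assay on HEL cells (Homo sapiens); on this read-out lower numbers stand for higher toxicity in this test and higher numbers for lower toxicity in this test; compound 4 `CCCCCCCCc1cc2cn(COCCO)c(O)nc-2n1` has not. In this assay compound 3 gives 140000 nM and compound 2 gives 41000 nM. For compound 1 the read-out in this assay is a limit of the assay, > 200000 nM, not a number. The difference between the core of compound 2 and the core of compound 3 is not broken down here. From compound 3 to compound 1 the change is hydrogen in place of propyl on a saturated chain carbon, four bonds along the chain from an aromatic carbon, and the step is an at least 1.4-fold higher number from compound 3 to compound 1 (0.15 log units; that floor lies within the scatter), a floor only, because it runs into (the limit of > 200000 nM in this assay, at which 1 of the 3 values shown sits). From compound 2 to compound 4 the change is hydrogen in place of propyl on a saturated chain carbon, eight bonds along the chain from an aromatic carbon: the same kind of change, with the place eight bonds along the chain from an aromatic carbon instead of four. The chain cut on the core of compound 2 is expected to move the number upward, so in this assay the expected step is a 2.4-fold higher number from compound 2 to compound 4 (0.39 log units; beyond the scatter), resting on compound 3 at 140000 nM as the shorter-chain point. Compound 4 is expected to give 100000 nM, within 40000 nM to 200000 nM.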

Compound 4, half-maximal cytotoxic concentration: 65000 nM
Beside the measured number, compound 4's estimate is 1.5-fold (0.19 log units) above it; the measured number falls inside the stated range.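

In this assay, the change from propyl to hydrogen on a saturated chain carbon, eight bonds along the chain from an aromatic carbon, gives a 1.6-fold higher number from compound 2 to compound 4 (0.20 log units; within the scatter), so on this core the chain cut does not stand clear of the usual scatter of repeated measurements. Set beside the same kind of change on the other core, the result shows neither that the step carries over at the same size nor that it differs between the two cores: the same change on two cores in this assay, an at least 1.4-fold higher number (0.15 log units; that floor lies within the scatter) from compound 3 to compound 1 and a 1.6-fold higher number (0.20 log units; within the scatter) from compound 2 to compound 4; the limit leaves it open whether they differ

The read-out of compound 1 is a limit of the assay and not a number, so the earlier step gives only a floor: the limit of > 200000 nM in this assay, at which 1 of the 4 values shown sits.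

The compounds shown include no pair that carries the same chain on the two cores, so any difference between the cores themselves stays open. Also open, as far as these compounds go, is what an amine, a carboxylic acid or a chain longer than that of compound 2 would give on either core in this assay.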